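This account rests on a few compounds, and the source may have more. Where it says the series, first, only, none or still open, it means among the compounds named here.

Values so far in a functional assay on MCF7 cells (Homo sapiens) for inhibition, read by MTT assay, with a stated time of 72 h (a higher number here means a weaker inhibitor, a lower number a stronger inhibitor), for the series:
- compound 1 `Brc1ccc(-c2nnc(SCCCN3CCN(c4nc5ccccc5o4)CC3)o2)cc1` gives 115000 nM
- compound 2 `Cc1ccc(-c2nnc(SCCCN3CCN(c4nc5ccccc5s4)CC3)o2)cc1` gives 107000 nM
- compound 3 `Fc1ccc(-c2nnc(SCCCN3CCN(c4nc5ccccc5s4)CC3)o2)cc1` gives 84100 nM

Compound 3 stands within the scatter of both compound 1 and compound 2, so the three values cannot be ranked and form a single group.

Compound 4 `Brc1ccc(-c2nnc(SCCCN3CCN(c4nc5ccccc5s4)CC3)o2)cc1` has bromo in place of the fluoro of compound 3 on an aromatic carbon, para to a large group, a change from 4-fluorophenyl to 4-bromophenyl (bromo in place of fluoro on an aromatic carbon). Among the measured compounds shown here, one measured step bears on this change: fluoro in place of methyl gave a 1.3-fold lower number from compound 2 to compound 3 (0.10 log units; within the scatter) and stays within the scatter. For the measured compounds named here, no measured pair compares bromo with fluoro directly. No step beyond the scatter is therefore expected in this assay for this exchange, and no direction is favoured. The estimate means a 1.1-fold higher number from compound 3 to compound 4 (0.04 log units; within the scatter) as an expected step within the scatter. Compound 4 is estimated at 92000 nM with a range of 52000 nM to 160000 nM in this series.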

Compound 4, half-maximal inhibitory concentration: 96300 nM
Beside the measured number, compound 4's estimate is 1.0-fold (0.02 log units) below it, and the stated range covers the measured number.
By their numbers in this assay, from the lowest: compounds 3, 4, 2 and 1 (each within the scatter of the next).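

In this assay, the place on the aromatic carbon para to a large group now carries three groups, with a 1.1-fold higher number from compound 3 to compound 4 (0.06 log units; within the scatter) and a 1.1-fold lower number from compound 2 to compound 4 (0.05 log units; within the scatter), so fluoro, methyl and bromo cannot be told apart there. Compound 4 also gives the series its first comparison at the other end of the molecule, with a 1.2-fold lower number from compound 1 to compound 4 (0.08 log units; within the scatter) for 1,3-benzothiazol-2-yl in place of 1,3-benzoxazol-2-yl on an amine nitrogen in a ring, and this exchange cannot be read as a difference either. Nothing available here accounts for these results.

Going by these compounds, whether a methoxy group, a nitrile or an amine at the same place would give a step beyond the scatter remains open. So does the effect of a longer chain on the sulfur.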